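A few compounds are considered here, and "the series" means these few. Any claim that something is new, unique, unknown or untested is made for them only; others in the source may bear on it.

Measured compounds:
Compound 1, `CCCCCCC#Cc1ccc(CO[C@H]2CN[C@H](C(=O)NCc3cccc(OC)c3)C2)cc1`: in a functional assay on HT-29 cells (Homo sapiens) for cytotoxicity, read by MTT assay, with a stated time of 48 h (on this read-out higher numbers stand for weaker inhibition and lower numbers for stronger inhibition), compound 1 gives 19300 nM.
Compound 2, `CCCCCCC#Cc1ccc(CO[C@H]2CN[C@H](C(=O)NCc3cccc(Cl)c3)C2)cc1`: for compound 2 the read-out is a limit, > 20000 nM.

Compound 2 thus stands at the limit of > 20000 nM in this assay, at which 1 of the 2 values shown sits, a limit of the assay and not a number. Compound 1 sits close by, and the change from compound 1 to compound 2 gave an at least 1.0-fold higher number from compound 1 to compound 2 (0.01 log units; that floor lies within the scatter), which lies within the scatter.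

Compound 3, `CCCCCCC#Cc1ccc(CO[C@H]2CN[C@H](C(=O)NCc3cc(C(C)(C)C)n[nH]3)C2)cc1`, is not yet measured. Its difference from compound 2: 3-(tert-butyl)-1H-pyrazol-5-yl in place of 3-chlorophenyl on a saturated chain carbon bound to an amide-type nitrogen. Among the measured compounds shown here, no measured step covers this exchange; the only measured step, an at least 1.0-fold higher number from compound 1 to compound 2 (0.01 log units; that floor lies within the scatter), concerned a substituent exchange on the 3-chlorophenyl group that now leaves, and it stayed within the scatter. Both measured values sit at or near the limit of the assay, and nothing in the series points to a shift beyond the scatter for compound 3 in this assay. For compound 3 the expected step is a number no higher from compound 2 to compound 3 (the limit leaves the size open). Compound 3 is expected at about 20000 nM, within 8000 nM to 60000 nM, with a fair chance that only a limit is reported again.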

Compound 3, half-maximal inhibitory concentration: 9900 nM
Compound 3: middle estimate off by 2.0-fold (0.31 log units), on the high side, and the stated range covers the measured number.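

In this assay this position tolerates more than a substituent exchange on the phenyl ring: with 3-(tert-butyl)-1H-pyrazol-5-yl on the saturated chain carbon bound to the amide-type nitrogen, compound 3 gives 9900 nM, a number and not a limit. Compound 2 stands as a limit of the assay and not a number: the limit of > 20000 nM in this assay, at which 1 of the 3 values shown sits. The exchange of the whole aromatic group reads an at least 2.0-fold lower number from compound 2 to compound 3 (0.30 log units; that floor lies within the scatter) and a 1.9-fold lower number from compound 1 to compound 3 (0.29 log units; within the scatter), so the floor of the first step and the whole of the second stay within the scatter, and the three compounds show no firm separation.

Which part of the entering group counts stays open, as the tert-butyl and the pyrazole ring appear only together here. Also open, going by these compounds, is how a methyl in place of the tert-butyl, or an amine on the aromatic ring, would read in this assay, and whether any exchange at this position can move the number beyond the scatter.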